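Pyridin-3-yl for Phenyl in a Small Series

The source may report more compounds than this note shows. Statements on the series, on what has been measured and on what is new or still open speak of the compounds shown alone.

Measured in a functional assay on the whole organism (strain Albino Wistar) for inhibition, with Rattus norvegicus as the target, read by paw edema, with stated times of 1 h and 3 h, at a dose of 10 mg/kg by the oral route; on this read-out lower numbers stand for less inhibition and higher numbers for more inhibition at the one dose given (going by the name of the read-out):
Compound 1 `Brc1ccc(-n2cc(CSc3nc4ccccc4s3)nn2)cc1`: 75%
Compound 2 `Cc1ccccc1-n1cc(CSc2nc3ccccc3s2)nn1`: 47.3%
Compound 3 `c1ccc(-n2cc(CSc3nc4ccccc4s3)nn2)cc1`: 46.7%

Compound 3 has the lowest of the three numbers, but its gap to compound 2 is small: a number 0.6 percentage points lower from compound 2 to compound 3 (within the scatter), within the scatter, so the two cannot be ordered. Only compound 1 stands clearly apart, as a number 28.3 percentage points lower from compound 1 to compound 3 (beyond the scatter) shows.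

Compound 4 `c1cncc(-n2cc(CSc3nc4ccccc4s3)nn2)c1` has not yet been measured in this assay. It differs from compound 3 in one place: pyridin-3-yl in place of phenyl on an aromatic nitrogen.

Among the measured compounds shown here, two measured steps bear on this change, since both alter the group on the same aromatic nitrogen: a number 27.7 percentage points lower from compound 1 to compound 2 (beyond the scatter) and a number 28.3 percentage points lower from compound 1 to compound 3 (beyond the scatter), each modest and beyond the scatter. Yet neither exchanges a ring atom for a heteroatom, and the one step between groups lacking bromo, a number 0.6 percentage points lower from compound 2 to compound 3 (within the scatter), lies within the scatter. Compound 4 is therefore expected to stay close to compound 3, with a step of a number 0.7 percentage points lower from compound 3 to compound 4 (within the scatter), not beyond the scatter. Compound 4 is estimated at 46%, in the range 32% to 62%.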

Compound 4, a percentage reported as inhibition, in the whole organism at one dose (the size of the read-out at that dose, not a potency): 64%
Estimate against measurement, compound 4: 18 percentage points below; the whole stated range lies below it.
By their numbers in this assay, from the lowest: compounds 3 and 2 (each within the scatter of the next); then compound 4; then compound 1.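

In this assay, the group on the aromatic nitrogen of the five-membered ring proves sensitive to a change of ring atom alone: pyridin-3-yl in place of phenyl gives a clear step (a number 17.3 percentage points higher from compound 3 to compound 4 (beyond the scatter)), whereas hydrogen in place of methyl had moved nothing beyond the scatter. Pyridin-3-yl also stands clear of 2-methylphenyl (a number 16.7 percentage points higher from compound 2 to compound 4 (beyond the scatter)) but falls short of 4-bromophenyl (a number 11 percentage points lower from compound 1 to compound 4 (beyond the scatter)), so 4-bromophenyl is no longer the only group here that stands apart from phenyl. Nothing among the data shown accounts for this rise.

The compounds shown leave open whether pyridin-2-yl or pyridin-4-yl would behave like pyridin-3-yl, and whether bromo on the pyridine ring would add to the step. They also do not show how a phenyl ring carrying an amine or a carboxylic acid would read.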